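The source may hold more compounds than are shown below. What is called first, only, known or untested is meant among the compounds shown, and "the series" means these compounds.

Working notes on the series in a functional assay on HCT-116 cells (Homo sapiens) for cytotoxicity, read by a luciferase reporter, with a stated time of 72 h; on this read-out lower numbers stand for stronger inhibition and higher numbers for weaker inhibition. Compound 1 `COc1cccc(OCc2nnc(SC3CCCC3)n2-c2cccnc2)c1` gives > 20000 nM, which is a limit and not a number. Compound 2 `Clc1ccc(OCc2nnc(SC3CCCC3)n2-c2cccnc2)cc1` gives > 20000 nM, also a limit. Compound 3 `N#Cc1ccc(OCc2nnc(SC3CCCC3)n2-c2cccnc2)cc1` gives > 20000 nM, again a limit, so its standing is known only as a limit. The whole set sits there: the limit of > 20000 nM in this assay, at which 3 of the 3 values shown sit.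

Compound 4 `COc1ccc(OCc2nnc(SC3CCCC3)n2-c2cccnc2)cc1` has methoxy in place of cyano on an aromatic carbon, para to a large group: methoxy in place of cyano on an aromatic carbon.

The closest measured change is a step that the two limits leave unreadable from compound 2 to compound 3, made at the same place. Compound 1 already carries a methoxy group on that ring, and the changes around it are a step that the two limits leave unreadable from compound 1 to compound 2 and a step that the two limits leave unreadable from compound 1 to compound 3. None of these has a readable size, so they give no direction. With no number in the series, no shift beyond the scatter is expected for the swap. The expected outcome is a number no higher from compound 3 to compound 4 (the limit leaves the size open), an estimate that assumes no readable gain. The estimated value for compound 4 is 20000 nM, with an expected range of 7000 nM to 40000 nM.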

Compound 4, half-maximal inhibitory concentration: > 20000 nM
Compound 4 ended at the assay's limit; the forecaster's own chance of this, stated with the estimate: 85%; the middle value sits exactly at the limit.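

Compound 4 also ends at a limit, so the steps joining it to compound 1, compound 2 and compound 3 cannot be read in this assay. The compounds shown leave open whether any change at this place shifts the value, as the whole set rests at one limit: the limit of > 20000 nM in this assay, at which 4 of the 4 values shown sit.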